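The source may report more compounds than this note shows. Statements on the series, on what has been measured and on what is new or still open speak of the compounds shown alone.

Three compounds have been measured in a physicochemical assay for acid dissociation, using potentiometric titration:

Compound 1 `CCCN1CCN(c2ccccc2C#N)CC1` gives 7.92.
Compound 2 `CCCN1CCN(c2ccc(C#N)cc2)CC1` gives 7.78.
Compound 3 `CCCN1CCN(c2ccccc2C(N)=O)CC1` gives 8.14.

Compound 3 differs from compound 1 by carbamoyl in place of cyano on an aromatic carbon, and in this assay the step is a number 0.22 log units higher from compound 1 to compound 3 (within the scatter). The difference between the cores of compound 1 and compound 2 is not broken down here; their values lie within the scatter of each other, while the values of compound 2 and compound 3 lie beyond it.

Compound 4 `CCCN1CCN(c2ccc(C(N)=O)cc2)CC1` is not yet measured. It differs from compound 2 by carbamoyl in place of cyano on an aromatic carbon. The surroundings are not identical: in compound 3 the entering group sits ortho to a group of 9 heavy atoms, in compound 4 para to a group of 9 heavy atoms, so this is the same kind of change rather than the same change. Resting on a number 0.22 log units higher from compound 1 to compound 3 (within the scatter), the step from compound 2 is expected to be a number 0.22 log units higher from compound 2 to compound 4 (within the scatter). Compound 4 is thus estimated at 8, between 7.7 and 8.3.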

Compound 4, acid dissociation constant: 7.84
Beside the measured number, compound 4's estimate is 0.16 log units above it; the measured number falls inside the stated range.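

In this assay, carbamoyl in place of cyano on an aromatic carbon gives a step on each of the two cores (a number 0.06 log units higher from compound 2 to compound 4 (within the scatter); a number 0.22 log units higher from compound 1 to compound 3 (within the scatter)). On both cores, the change leaves the number within the scatter, so in these two pairs it carries over as a change that cannot be told from repeat measurement, though this does not establish a real shift on either core or a difference between the two steps. Nothing shown accounts for this outcome on either core.

From the compounds shown here alone, whether a carboxylic acid or an amine in place of cyano would also stay within the scatter remains open. So does the outcome of a longer chain in place of the one on the shared core.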